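Removing the nitrile on a weakly inhibitory series

The source may hold more compounds than are shown below. What is called first, only, known or untested is meant among the compounds shown, and "the series" means these compounds.

Compound 3 `N#Cc1ccc(-c2cnc3[nH]cc(-c4nnc(-c5ccc(Cl)cc5)o4)c(=O)c3c2)cc1` gives the highest of the three numbers measured in a functional assay on MCF7 cells (Homo sapiens) for inhibition, read by MTT assay, with a stated time of 24 h, tested at 5 uM (on this read-out lower numbers stand for less inhibition of growth and higher numbers for more inhibition of growth at the one concentration tested), standing at 4.65%; its nearest neighbour compound 1 `CS(=O)(=O)c1ccc(-c2cnc3[nH]cc(-c4nnc(-c5ccccc5)o4)c(=O)c3c2)cc1` gives 1.38%, and compound 2 `CS(=O)(=O)c1ccc(-c2cnc3[nH]cc(-c4nnc(-c5ccc(Cl)cc5)o4)c(=O)c3c2)cc1` gives 0.86%, both of them separated from compound 3 by no more than the usual scatter. Compound 4 `O=c1c(-c2nnc(-c3ccc(Cl)cc3)o2)c[nH]c2ncc(-c3ccccc3)cc12` differs from compound 3 by hydrogen in place of cyano on an aromatic carbon. Within the data shown here, two steps bear on it: a number 0.5 percentage points lower from compound 1 to compound 2 (within the scatter), where a hydrogen on an aromatic carbon was replaced, and a number 3.8 percentage points higher from compound 2 to compound 3 (within the scatter), where the cyano itself entered. Neither moved beyond the scatter, so compound 4 is expected to show no step beyond the scatter, estimated at a number 1.7 percentage points lower from compound 3 to compound 4 (within the scatter). Compound 4 is therefore estimated to give 3%, within a range of -3% to 12%.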

Compound 4, percent growth inhibition at one concentration: 12%
Compound 4: middle estimate off by 9 percentage points, on the low side, within the range that was stated.
By their numbers in this assay, from the lowest: compounds 2, 1, 3 and 4 (each within the scatter of the next, the first and the last beyond it).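

In this assay hydrogen in place of cyano gives a number 7.4 percentage points higher from compound 3 to compound 4 (within the scatter) and so cannot be told from no change at this position, para to a large group. Hydrogen in place of methylsulfonyl on the same carbon gives a number 11.1 percentage points higher from compound 2 to compound 4 (beyond the scatter) and is the only step shown that exceeds the scatter, though modestly. As far as these compounds go, whether an amine or a carboxylic acid on this carbon would move the number stays open, as does whether the phenyl compound would hold its number without the chloro. No evidence is available that bears on this result.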